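A few compounds are considered here, and "the series" means these few. Any claim that something is new, unique, unknown or untested is made for them only; others in the source may bear on it.

Compound 1 `COc1ccc(-c2nc(C(=O)/C=C\Nc3ccc(F)cc3)c3ccccn23)cc1`. In a functional assay on A549 cells (Homo sapiens) for cytotoxicity, read by MTT assay, with a stated time of 48 h (a higher number here means a weaker inhibitor, a lower number a stronger inhibitor), compound 1 gives > 30000 nM, which is a limit of the assay rather than a number.
Compound 2 `O=C(/C=C\Nc1ccc2cc[nH]c2c1)c1nc(-c2ccc(C(F)(F)F)cc2)n2ccccc12`. In this assay compound 2 gives > 30000 nM, again a limit.
Compound 3 `COc1ccc(-c2nc(C(=O)/C=C\Nc3ccc4[nH]ccc4c3)c3ccccn23)cc1`. In this assay compound 3 gives 4800 nM.

Compound 1 thus stands at the limit of > 30000 nM in this assay, at which 2 of the 3 values shown sit. Within the data shown here, the only measured step, an at least 6.2-fold lower number from compound 1 to compound 3 (0.79 log units; beyond the scatter), concerns the group on the amine nitrogen, not the aryl ring that changes here. Compound 4 `O=C(/C=C\Nc1ccc(F)cc1)c1nc(-c2ccc(F)cc2)n2ccccc12` differs from compound 1 by fluoro in place of methoxy on an aromatic carbon. Among the measured compounds shown here, no measured step bears on this change, so no step beyond the scatter is expected in this assay and a further limit is the likeliest outcome. Compound 4 is therefore estimated at 40000 nM, within 15000 nM to 100000 nM. That estimate would mean a step that the limit leaves unreadable from compound 1 to compound 4.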

Compound 4, half-maximal inhibitory concentration: 13200 nM
The estimate for compound 4 lay 3.0-fold (0.48 log units) above the measured number, outside the stated range (below it).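

In this assay, fluoro in place of methoxy gives the first readable movement at this aryl position, with an at least 2.2-fold lower number from compound 1 to compound 4 (0.35 log units; beyond the scatter). The aromatic carbon para to a large group therefore affects the read-out, which the earlier step on the amine nitrogen could not show. The full size of this step stays unknown because the value of compound 1 is a limit of the assay: the limit of > 30000 nM in this assay, at which 2 of the 4 values shown sit.

As far as these compounds go, it remains open whether a chloro group or an amine at this place would lower the number further. From the compounds shown here alone, it also remains open whether the same change would give a similar step with the 1H-indol-5-yl group of compound 3 on the amine nitrogen.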